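Fluoro Added to the Methoxyphenyl Arm: Cytotoxicity Outlook

A few compounds are considered here, and "the series" means these few. Any claim that something is new, unique, unknown or untested is made for them only; others in the source may bear on it.

Compound 1 `CCOC(=O)CCCCCOc1cccc(CN(C(=O)c2ccccc2)C(C)C)c1` is the parent of this small set. In an ADME assay on HEK293 cells (Homo sapiens) for cytotoxicity, read by CellTiter-Glo and resazurin assay, with a stated time of 72 h (a lower number here means that less compound is needed, a higher number that more compound is needed for the effect), compound 1 gives > 26000 nM, which is a limit of the assay rather than a number. Compound 2 `CCOC(=O)CCCCCOc1cccc(CN(C(=O)c2ccc(-c3cnc(OC)nc3OC)cc2)C(C)C)c1` carries 2,4-dimethoxypyrimidin-5-yl in place of hydrogen on an aromatic carbon; in this assay compound 2 gives > 26000 nM, again a limit. Compound 3 `CCOC(=O)CCCCCOc1cccc(CN(C(=O)c2ccc(-c3cccc(OC)c3)cc2)C(C)C)c1` carries 3-methoxyphenyl in place of hydrogen on an aromatic carbon, and in this assay compound 3 gives > 21000 nM, also a limit. The three steps among these compounds are a step that the two limits leave unreadable from compound 1 to compound 2, a step that the two limits leave unreadable from compound 1 to compound 3 and a step that the two limits leave unreadable from compound 2 to compound 3: because every value sits at the limit of > 21000 nM in this assay, at which 1 of the 3 values shown sits, or at the limit of > 26000 nM in this assay, at which 2 of the 3 values shown sit, their sizes cannot be read, and compound 3 stands no differently from the other two on what is shown.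

Compound 4 `CCOC(=O)CCCCCOc1cccc(CN(C(=O)c2ccc(-c3cc(OC)ccc3F)cc2)C(C)C)c1` differs from compound 3 by fluoro in place of hydrogen on an aromatic carbon. No measured step bears directly on this change, and the three steps shown, all unreadable, give no direction to expect. Compound 4 is therefore expected to show a step that the limit leaves unreadable from compound 3 to compound 4, that is, no step beyond the scatter. Compound 4 is estimated at 30000 nM, within 14000 nM to 70000 nM, and is most likely to be reported again only as a limit.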

Compound 4, half-maximal effective concentration: > 26000 nM
Compound 4: a limit, no number; the forecaster's own chance of this, stated with the estimate: 85%; the middle value is on the limit's open side.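

In this assay compound 4 gives > 26000 nM, which is a limit of the assay and not a number. Within the data shown here, no step from compound 1, compound 2 or compound 3 to compound 4 can be read. The compounds shown leave open the half-maximal effective concentration of all four, and whether fluoro in place of hydrogen changes it at all.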